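This account rests on a few compounds, and the source may have more. Where it says the series, first, only, none or still open, it means among the compounds named here.

Measured compounds:
- compound 1 `CN(C)c1cccc(Oc2ccc(N3CCC[C@H]3CC(=O)O)cc2)c1` gives > 33000 nM in a functional assay on cells for agonist activity at Free fatty acid receptor 1 (Mus musculus), read by FLIPR and calcium flux, with a stated time of 100 s (on this read-out higher numbers stand for an effect only at larger amounts of compound and lower numbers for an effect already at smaller amounts), which is a limit of the assay and not a number.
- compound 2 `Cc1cc(OCc2ccccc2)ccc1Oc1ccc(N2C[C@@H](C(F)(F)F)C[C@H]2CC(=O)O)cc1` gives 1500 nM in this assay.
- compound 3 `COc1ccc(Oc2ccc(N3C[C@@H](C(F)(F)F)C[C@H]3CC(=O)O)cc2)c(C)c1` gives 170 nM in this assay.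

Compound 3 has the lower of the two measured numbers. Going by the values given here, its nearest neighbour is compound 2, and the step between them, an 8.8-fold lower number from compound 2 to compound 3 (0.95 log units; beyond the scatter), is the only measured step in this set. Of compound 1 only this much can be said: it sits at the limit of > 33000 nM in this assay, at which 1 of the 3 values shown sits.

Compound 4 `Cc1cccc(C)c1Oc1ccc(N2C[C@@H](C(F)(F)F)C[C@H]2CC(=O)O)cc1` differs from compound 3 in one place: 2,6-dimethylphenyl in place of 4-methoxy-2-methylphenyl on an oxygen on an aromatic ring. Among the compounds with values here, the one measured step, an 8.8-fold lower number from compound 2 to compound 3 (0.95 log units; beyond the scatter), concerns a chain carbon bound to an oxygen on an aromatic ring and not the aromatic ring that is exchanged here, so it gives no direct guide to the present change. Within the data shown here, the compounds measured so far show no example of swapping one substituted phenyl ring for another on this oxygen. The change is expected to move the number only modestly, with a somewhat higher number judged a little more likely than a lower one, but no shift beyond the scatter can be firmly expected; the step from compound 3 to compound 4 is therefore estimated as a 1.8-fold higher number from compound 3 to compound 4 (0.25 log units; within the scatter). Compound 4 is estimated to give 300 nM in this assay, within a range from 80 nM to 1200 nM.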

Compound 4, half-maximal effective concentration: 270 nM
Beside the measured number, compound 4's estimate is 1.1-fold (0.05 log units) above it, and the stated range covers the measured number.
By their numbers in this assay, from the lowest: compounds 3 and 4 (each within the scatter of the next); then compound 2. At a limit, above all of these: compound 1.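

In this assay, placing 2,6-dimethylphenyl where 4-methoxy-2-methylphenyl stood, on an oxygen on an aromatic ring, gives a 1.6-fold higher number from compound 3 to compound 4 (0.20 log units; within the scatter), so this read-out does not separate the two groups. Going by these compounds alone, this is the first exchange of one substituted phenyl ring for another at this place; the only earlier step, an 8.8-fold lower number from compound 2 to compound 3 (0.95 log units; beyond the scatter), concerned a chain carbon bound to an oxygen on an aromatic ring and lay beyond the scatter, whereas here the methoxy group goes and a methyl group stands in a new place on the ring without a step beyond the scatter. Nothing measured here gives a reason for this result.

On these data alone, it remains open whether a phenyl ring carrying a nitrile, a chlorine or a carboxylic acid on this oxygen would also stay within the scatter of compound 3. This single pair also cannot show which of the two differences between the rings, the loss of the methoxy group or the new place of the methyl group, matters more in this assay, since both change together.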